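Swapping the aryl group on the hydrazone carbon of compound 3

The source may report more compounds than this note shows. Statements on the series, on what has been measured and on what is new or still open speak of the compounds shown alone.

Of the compounds shown here, three sharing one core have been tested in a functional assay on A549 cells (Homo sapiens) for cytotoxicity, read by MTT assay, with a stated time of 72 h; a lower number here means a stronger inhibitor, a higher number a weaker inhibitor. Compound 1 `CN(C)CCn1cnnc1-c1cc(Oc2ccc(NC(=O)N/N=C/c3ccc(Cl)cc3Cl)cc2F)ccn1` gives 810 nM. Compound 2 `COc1ccc(/C=N/NC(=O)Nc2ccc(Oc3ccnc(-c4nncn4CCN(C)C)c3)c(F)c2)c(OC)c1` gives 2820 nM. Compound 3 `CN(C)CCn1cnnc1-c1cc(Oc2ccc(NC(=O)N/N=C/c3ccc(O)c(Br)c3)cc2F)ccn1` gives 1370 nM, the second highest of the three numbers; its nearest neighbour is compound 1, with a 1.7-fold higher number from compound 1 to compound 3 (0.23 log units; within the scatter), and its furthest is compound 2, with a 2.1-fold lower number from compound 2 to compound 3 (0.31 log units; beyond the scatter).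

Compound 4 `COc1ccc(/C=N/NC(=O)Nc2ccc(Oc3ccnc(-c4nncn4CCN(C)C)c3)c(F)c2)c(OC)c1OC` has not yet been tested. It differs from compound 3 in one place: 2,3,4-trimethoxyphenyl in place of 3-bromo-4-hydroxyphenyl on a carbon with a double bond to nitrogen. Within the data shown here, the step that bears most directly on this change is the one from the dimethoxy analogue to the bromo-hydroxy analogue, a 2.1-fold lower number from compound 2 to compound 3 (0.31 log units; beyond the scatter), which ran toward a lower number; the related step of a 3.5-fold higher number from compound 1 to compound 2 (0.54 log units; beyond the scatter) also shows that a methoxy-bearing aryl gave a higher number than a halogen-bearing one. Since the change from compound 3 to compound 4 moves back toward a methoxy-bearing aryl, a modest rise in this assay is expected, on the order of a 2.0-fold higher number from compound 3 to compound 4 (0.31 log units; beyond the scatter). Compound 4 is therefore estimated at 2800 nM, with a likely range from 1200 nM to 6500 nM.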

Compound 4, half-maximal inhibitory concentration: 6680 nM
Beside the measured number, compound 4's estimate is 2.4-fold (0.38 log units) below it, outside the stated range (above it).
By their numbers in this assay, from the lowest: compounds 1 and 3 (each within the scatter of the next); then compound 2; then compound 4.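

In this assay the step of a 2.4-fold higher number from compound 2 to compound 4 (0.37 log units; beyond the scatter) comes from a single change, methoxy in place of hydrogen on an aromatic carbon, so in this pair a further methoxy on the aryl ring raises the number rather than leaving it within the scatter. The step of a 4.9-fold higher number from compound 3 to compound 4 (0.69 log units; beyond the scatter) and the step of an 8.2-fold higher number from compound 1 to compound 4 (0.92 log units; beyond the scatter) are the widest seen at this position, and they set 2,3,4-trimethoxyphenyl well apart from both 3-bromo-4-hydroxyphenyl and 2,4-dichlorophenyl. Nothing measured here explains these steps.

Open, from the compounds shown here alone, is whether the rise follows the number of methoxy groups or where they sit on the ring, which a 3,4,5-trimethoxyphenyl group would help separate. Also open, going by these compounds, is how an aryl ring carrying a dimethylamino group or a carboxylic acid would compare at this position.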